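The source may hold more compounds than are shown below. What is called first, only, known or untested is meant among the compounds shown, and "the series" means these compounds.

Measured compounds in a functional assay on MCF7 cells (Homo sapiens) for cytotoxicity, read by MTT assay, with a stated time of 48 h; a lower number here means a stronger inhibitor, a higher number a weaker inhibitor:
Compound 1 `CCCCCCCCCCCCCCCCCCNC(=O)[C@@H](N)[C@@H](C)O` gives 27400 nM.
Compound 2 `CCCCCCCCNC(=O)[C@@H](NC(=O)c1ccco1)[C@@H](C)O` gives 91800 nM.
Compound 3 `CCCCCCCCCCCCCCNC(=O)[C@@H](NC(=O)c1ccccc1)[C@@H](C)O` gives 24800 nM.

Among these three numbers compound 1 holds the second highest. Its nearest neighbour is compound 3, whose number lies within the usual scatter of that of compound 1, so no order between the two can be read. Compound 2 stands furthest away, with a number higher than that of compound 1 by a margin beyond the scatter. The unmeasured compound 4 `CCCCCCCCCCCCCCCCCCNC(=O)[C@@H](NS(=O)(=O)c1ccc(C)cc1)[C@@H](C)O` keeps the saturated chain and the core of compound 1 and differs from it in one place: (4-methylphenyl)sulfonyl in place of hydrogen on an amine nitrogen. Among the measured compounds shown here, no pair of measured compounds differs by this change alone, so no measured step shows its effect. Compound 3 also carries a substituent in place of hydrogen on the amine nitrogen and gives a number close to that of compound 1, which suggests that such substitution need not move the number far. Compound 4 is therefore expected to give 30000 nM in this assay, with a range from 10000 nM to 90000 nM. The step of a 1.1-fold higher number from compound 1 to compound 4 (0.04 log units; within the scatter) is expected to stay within the scatter.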

Compound 4, half-maximal inhibitory concentration: 60100 nM
Beside the measured number, compound 4's estimate is 2.0-fold (0.30 log units) below it; the measured number falls inside the stated range.
By their numbers in this assay, from the lowest: compounds 3 and 1 (each within the scatter of the next); then compounds 4 and 2 (each within the scatter of the next).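

In this assay, among the compounds shown here, (4-methylphenyl)sulfonyl in place of hydrogen on the amine nitrogen gives a 2.2-fold higher number from compound 1 to compound 4 (0.34 log units; beyond the scatter), the first step that can be read at this position. It shows that this change moves the number beyond the scatter, yet only modestly, so the substituted compound 4 remains measurable at 60100 nM and keeps a number of the same general order as that of its parent. Nothing available bears on the reason for this step.

On these data alone, it remains open whether the sulfonyl link or the 4-methylphenyl ring accounts for the step, a question that methanesulfonyl or benzoyl on the same nitrogen, with the chain of compound 1 kept, could address. Also open, as far as these compounds go, is whether chloro or methoxy in place of the ring methyl would change the number.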